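The source may hold more compounds than are shown below. What is called first, only, known or untested is meant among the compounds shown, and "the series" means these compounds.

Measured so far in an assay on cells for binding affinity to Neuropeptide Y receptor type 1 (Homo sapiens); on this read-out lower numbers stand for stronger inhibition and higher numbers for weaker inhibition:
compound 1 `CCc1sc(CCc2cc(OC)cc(NCc3cc(Cl)cc(NC(=O)OC(C)C)c3)n2)nc1C` gives 234 nM
compound 2 `CCCCCCCOc1cc(CCc2nc(C)c(CC)s2)nc(NCc2cc(Cl)cc(NC(=O)OC(C)C)c2)c1` gives 72 nM
compound 3 `CCc1sc(CCc2cc(OC3CCOCC3)cc(NCc3cc(Cl)cc(NC(=O)OC(C)C)c3)n2)nc1C` gives 4.4 nM

Compound 1 stands highest of the three numbers in this assay; its nearest neighbour is compound 2, with a 3.3-fold lower number from compound 1 to compound 2 (0.51 log units; beyond the scatter), and the furthest is compound 3, with a 53-fold lower number from compound 1 to compound 3 (1.73 log units; beyond the scatter). Both steps from compound 1 lie beyond the scatter. The remaining step, a 16-fold lower number from compound 2 to compound 3 (1.21 log units; beyond the scatter), also lies beyond the scatter.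

Compound 4 `CCc1sc(CCc2cc(OCCCc3cccnc3)cc(NCc3cc(Cl)cc(NC(=O)OC(C)C)c3)n2)nc1C` has not yet been measured. It differs from compound 1 by 2-(pyridin-3-yl)ethyl in place of hydrogen on a saturated chain carbon bound to an oxygen on an aromatic ring. Within the data shown here, the step that bears most directly on this is the one from compound 1 to compound 2, where a longer chain entered at the same place and gave a 3.3-fold lower number from compound 1 to compound 2 (0.51 log units; beyond the scatter). The step to compound 3 involved a different position and a different kind of group, so it is a weaker guide. A lowering beyond the scatter is therefore expected for compound 4, on the order of the step to compound 2 and possibly somewhat larger, that is a 5.2-fold lower number from compound 1 to compound 4 (0.72 log units; beyond the scatter). The estimate for compound 4 in this assay is 45 nM, with a range from 10 nM to 160 nM.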

Compound 4, half-maximal inhibitory concentration: 6.5 nM
Compound 4: middle estimate off by 6.9-fold (0.84 log units), on the high side; the measured number lies below the stated range.
By their numbers in this assay, from the lowest: compounds 3 and 4 (each within the scatter of the next); then compound 2; then compound 1.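

In this assay the 3-(pyridin-3-yl)propyl group on the oxygen gives a 36-fold lower number from compound 1 to compound 4 (1.56 log units; beyond the scatter) and so goes well past what the plain chain of compound 2 achieved. Chain length alone therefore does not set the number at this position: pyridin-3-yl in place of butyl at the end of the chain gives an 11-fold lower number from compound 2 to compound 4 (1.04 log units; beyond the scatter) as a further large step. Two quite different groups on this oxygen also cannot be told apart, since oxan-4-yl and 3-(pyridin-3-yl)propyl are separated only by a 1.5-fold higher number from compound 3 to compound 4 (0.17 log units; within the scatter) and that step lies within the scatter.

From the compounds shown here alone, it remains open whether a phenyl ring or a dimethylamino group at the end of the same chain, or a pyridin-3-yl on a shorter chain, would hold this level. Nothing measured here gives a reason for the result.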